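Three Inactive Sulfonyl Analogues and a Pentafluorophenyl Successor

The source may report more compounds than this note shows. Statements on the series, on what has been measured and on what is new or still open speak of the compounds shown alone.

Measured compounds:
- Compound 1 `COc1ccc(-c2cc(=O)c3c(OC)cc(OC)cc3n2S(=O)(=O)c2ccc([N+](=O)[O-])cc2)cc1`: in a functional assay on HepG2 cells (Homo sapiens) for antiproliferative activity, with a stated time of 72 h (a lower number here means that less compound is needed, a higher number that more compound is needed for the effect), compound 1 gives only a limit, > 29300 nM.
- Compound 2 `COc1ccc(-c2cc(=O)c3c(OC)cc(OC)cc3n2S(=O)(=O)c2ccc(C#N)cc2)cc1`: in this assay compound 2 gives only a limit, > 17200 nM.
- Compound 3 `COc1ccc(-c2cc(=O)c3c(OC)cc(OC)cc3n2S(=O)(=O)c2ccc(F)cc2)cc1`: in this assay compound 3 gives only a limit, > 65500 nM.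

All three compounds share one core and differ only in the group on the sulfonyl sulfur. None of them reached a measurable value: each result is a limit of the assay, and compound 3 therefore cannot be placed relative to the other two. The steps among them, a step that the two limits leave unreadable from compound 1 to compound 2, a step that the two limits leave unreadable from compound 1 to compound 3 and a step that the two limits leave unreadable from compound 2 to compound 3, are unreadable in size, since both ends of each step sit at a limit, as the entries (the limit of > 17200 nM in this assay, at which 1 of the 3 values shown sits), the limit of > 29300 nM in this assay, at which 1 of the 3 values shown sits, and the limit of > 65500 nM in this assay, at which 1 of the 3 values shown sits, show.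

Compound 4 `COc1ccc(-c2cc(=O)c3c(OC)cc(OC)cc3n2S(=O)(=O)c2c(F)c(F)c(F)c(F)c2F)cc1` carries the change (2,3,4,5,6-pentafluorophenyl in place of 4-fluorophenyl on a sulfonyl sulfur). Among the compounds with values here, no measured step shows how the sulfonyl aryl group affects this assay, so the only guide is that three different groups on that sulfur all left the compound without a measurable effect. Compound 4 is therefore expected to remain weak as well, with an estimated value of 60000 nM (range 10000 nM to 300000 nM). The expected step of an at least 1.0-fold lower number from compound 3 to compound 4 (0.03 log units; that floor lies within the scatter) is thus essentially none beyond the scatter, and most likely the assay will again report only a limit.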

Compound 4, half-maximal effective concentration: > 34400 nM
Compound 4: no number, only a limit (the forecaster's own chance of this, stated with the estimate: 80%); the middle value does not contradict the limit.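

In this assay compound 4 gives only a limit, > 34400 nM. All four compounds sit at limits, so the steps to compound 4 from compound 1, compound 2 and compound 3 cannot be read. The compounds shown leave open whether any group on the sulfonyl sulfur gives a measurable value in this assay.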